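Series notes: the sulfur substituent, compound 2 to compound 3

The source may hold more compounds than are shown below. What is called first, only, known or untested is meant among the compounds shown, and "the series" means these compounds.

Values in a functional assay on BGC-823 cells (Homo sapiens) for inhibition, read by MTT assay, with a stated time of 72 h; a higher number here means a weaker inhibitor, a lower number a stronger inhibitor:
Compound 1 `Cc1cc(N2CC[C@@H](C)[C@@H](N(C)c3ncnc4[nH]ccc34)C2)n2nc(SCc3nc4ccccc4[nH]3)nc2n1`: > 100000 nM (a limit)
Compound 2 `C=CCSc1nc2nc(C)cc(N3CC[C@@H](C)[C@@H](N(C)c4ncnc5[nH]ccc45)C3)n2n1`: 40900 nM

For the measured compounds named here, compound 2 holds the only actual number in this assay, at 40900 nM. Compound 1 stands at a limit, > 100000 nM. Compound 3 `Cc1cc(N2CC[C@@H](C)[C@@H](N(C)c3ncnc4[nH]ccc34)C2)n2nc(SCc3cc(Cl)ccc3Cl)nc2n1` carries 2,5-dichlorophenyl in place of vinyl on a saturated chain carbon bound to a sulfur.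

Going by the values given here, one measured step bears on this change, made at the same place: an at least 2.4-fold lower number from compound 1 to compound 2 (0.38 log units; beyond the scatter). Since that step starts from a limit, its true size is open. Among the compounds with values here, compound 3 again has an aromatic ring at this place, as compound 1 does, so the risk lies towards a higher number, though no step clearly beyond the scatter is expected. The estimate means a 1.5-fold higher number from compound 2 to compound 3 (0.17 log units; within the scatter), as an expected step. For compound 3 the expected value is 60000 nM, with an estimated range of 20000 nM to 150000 nM.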

Compound 3, half-maximal inhibitory concentration: 18900 nM
Compound 3: middle estimate off by 3.2-fold (0.50 log units), on the high side, and the stated range ends above it.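

In this assay, 2,5-dichlorophenyl in place of vinyl gives a 2.2-fold lower number from compound 2 to compound 3 (0.34 log units; beyond the scatter), so an aromatic ring at this place does not of itself raise the number. The ring's identity matters here, as 2,5-dichlorophenyl in place of 1H-benzimidazol-2-yl gives an at least 5.2-fold lower number from compound 1 to compound 3 (0.72 log units; beyond the scatter). Compound 1 stands at a limit, so the true size of that step is open: the limit of > 100000 nM in this assay, at which 1 of the 3 values shown sits.

The compounds shown do not separate the contribution of the aromatic ring from that of its two chlorine atoms, and a plain benzyl on the sulfur would read the ring alone. On these data alone, how a chain ending in an amine or a carboxylic acid would read at this place also remains open.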